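The compounds below may be only part of what the source reports. "The series", "measured", "known", "first", "only" and "open" are said of these compounds alone.

Measured in a physicochemical assay for lipophilicity, using the shake flask method, measured as octanol-water partition, at pH 7.4; a lower number here means a more polar compound, a higher number a more lipophilic compound:
- compound 1 `CC(C)n1nc(-c2ccnc3[nH]c(C4CCN(CC(=O)N(C)C)CC4)cc23)ccc1=O` gives 2
- compound 2 `CC(C)n1cc(-c2ccnc3[nH]c(C4CCN(Cc5cccs5)CC4)cc23)ccc1=O` gives 3.4
- compound 3 `COc1cc(F)ccc1-c1ccnc2[nH]c(C3CCNCC3)nc12` gives 0

Compound 1 stands in the middle of these three numbers. Compound 2 lies above it and compound 3 lies below it, and both gaps are beyond the usual scatter. Going by the values given here, the three compounds differ from one another in more than one place, so they offer no measured step for a single change.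

The next compound to be measured is compound 4 `CCn1cc(-c2ccnc3[nH]c(C4CCN(CC(=O)N(C)C)CC4)cc23)ccc1=O`, which keeps the core of compound 1 and differs from it in one place. On an aromatic carbon of a six-membered aromatic ring with 1 nitrogen, part of a fused or bridged system of two rings, opposite the ring nitrogen, the structure changes as follows: a group of 9 heavy atoms (7 carbon, 1 nitrogen, 1 oxygen; one six-membered aromatic ring with 1 hetero atom) in place of a group of 10 heavy atoms (7 carbon, 2 nitrogen, 1 oxygen; one six-membered aromatic ring with 2 hetero atoms), on an aromatic carbon. The group that enters is only slightly smaller than the one that leaves, and the rest of the molecule is untouched.

Among the compounds with values here, with no measured step to draw on, a small downward move in this assay is expected, no larger than the usual scatter. The expected change is a number 0.20 log units lower from compound 1 to compound 4 (within the scatter). For compound 4 the estimated value is 1.8, with an expected range of 1.3 to 2.3.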

Compound 4, distribution coefficient: 1.2
For compound 4 the middle estimate is 0.60 log units above the measured one, and the stated range ends above it.
By their numbers in this assay, from the lowest: compound 3; then compound 4; then compound 1; then compound 2.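

Going by these compounds alone, at this aromatic carbon, opposite the ring nitrogen, the earlier compounds offered no measured step, and a number 0.80 log units lower from compound 1 to compound 4 (beyond the scatter) is the first one available in this assay for the core of compound 1. It shows that exchanging a group of 10 heavy atoms for a group of 9 heavy atoms at this position, with the rest of the molecule untouched, is enough to move the number beyond the scatter. No measurement is at hand that bears on the cause of this step.

The exchange replaces a six-membered aromatic ring with 2 hetero atoms by one with 1 hetero atom and also replaces an isopropyl group by an ethyl group, so this single step cannot say how much of it belongs to the ring and how much to the alkyl group. Also open, going by these compounds, is how the number would read with a methyl or cyclopropyl group in place of the ethyl group on the ring that enters here.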